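A few compounds are considered here, and "the series" means these few. Any claim that something is new, unique, unknown or untested is made for them only; others in the source may bear on it.

Measured compounds:
- compound 1, `C#CCN1CCC(COC(=O)Nc2ccc(C(C)C)cc2)CC1`: > 100000 nM
- compound 2, `CC(C)c1ccc(NC(=O)OCC2CCN(Cc3ccccc3)CC2)cc1`: > 100000 nM
- compound 3, `C#CCN1CCC(COC(=O)N(C)CC)CC1`: > 100000 nM

Three carbamates were tested in an assay on BTI-TN-5B1-4 cells for inhibition of Amine oxidase [flavin-containing] A (Homo sapiens), read by fluorescence and Amplex Red, using microsomes, with a stated time of 15 min; on this read-out higher numbers stand for weaker inhibition and lower numbers for stronger inhibition. In this assay compound 1 gives > 100000 nM, which is a limit of the assay rather than a number. In this assay compound 2 gives > 100000 nM, again a limit. In this assay compound 3 gives > 100000 nM, also a limit. All three values therefore sit at the limit of > 100000 nM in this assay, at which 3 of the 3 values shown sit.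

Compound 2 differs from compound 1 in one place: phenyl in place of ethynyl on a saturated chain carbon bound to an amine nitrogen in a ring. The step it makes is a step that the two limits leave unreadable from compound 1 to compound 2, because both ends rest on (the limit of > 100000 nM in this assay, at which 3 of the 3 values shown sit).

Compound 4, `CCN(C)C(=O)OCC1CCN(Cc2ccccc2)CC1`, has not yet been measured in this assay. It differs from compound 3 by phenyl in place of ethynyl on a saturated chain carbon bound to an amine nitrogen in a ring, the same change as that from compound 1 to compound 2, made on the same kind of position. The two cores, that of compound 1 and that of compound 3, differ by a part of the molecule that is not broken down here.

Given that compound 3 gives > 100000 nM and that the same change left compound 1 and compound 2 at the limit of > 100000 nM in this assay, at which 3 of the 3 values shown sit, compound 4 is expected to make a step that the limit leaves unreadable from compound 3 to compound 4, which is not readable in size. Compound 4 is therefore estimated at 150000 nM, within 40000 nM to 600000 nM, most likely reported once more as a limit of this assay.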

Compound 4, half-maximal inhibitory concentration: > 100000 nM
Compound 4 ended at the assay's limit; the forecaster's own chance of this, stated with the estimate: 85%; the middle value does not contradict the limit.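

No step can be read from compound 3 to compound 4 in this assay, because both compounds rest on the same limit, as does every other compound shown: the limit of > 100000 nM in this assay, at which 4 of the 4 values shown sit.

The compounds shown leave open how the change from propargyl to benzyl would read in this assay on any compound with a measurable value, since none of them has a value that is more than a limit.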